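Swapping a Urea Arm for a Dichlorophenyl Amide

This account rests on a few compounds, and the source may have more. Where it says the series, first, only, none or still open, it means among the compounds named here.

Compound 2 `COc1cc(Cl)cc(-c2nn(-c3cccc(NC(=O)Nc4ccc(Cl)c(C(F)(F)F)c4)c3)cc2-c2ccncc2)c1` stands second highest among three measured numbers: in a functional assay on NCI-H460 cells (Homo sapiens) for inhibition, read by sulforhodamine B assay, with a stated time of 48 h, tested at 10 uM (on this read-out lower numbers stand for a stronger effect and higher numbers for a weaker effect at the one concentration tested), compound 2 gives 2.76%. Compound 1 `COc1cc(Cl)cc(-c2nn(-c3cccc(NC(=O)Nc4cccc(C(F)(F)F)c4)c3)cc2-c2ccncc2)c1` gives -6.11%, and a number 8.9 percentage points higher from compound 1 to compound 2 (within the scatter). Compound 3 `COc1cc(Cl)cc(-c2nn(-c3cccc(NC(=O)c4cc(C(F)(F)F)cc(C(F)(F)F)c4)c3)cc2-c2ccncc2)c1` gives 41%, a higher number than compound 2 by more than the scatter. The unmeasured compound 4 `COc1cc(Cl)cc(-c2nn(-c3cccc(NC(=O)c4ccc(Cl)c(Cl)c4)c3)cc2-c2ccncc2)c1` differs from compound 2 in one place (3,4-dichlorophenyl in place of (4-chloro-3-(trifluoromethyl)phenyl)amino on a carbonyl carbon). Among the measured compounds shown here, no measured step matches this exchange; the step from compound 1 to compound 2 concerns only chloro in place of hydrogen on an aromatic carbon and was small. Because compound 3 gives 41% with an aryl group directly on the carbonyl carbon, a higher number is expected for compound 4. Compound 4 is estimated at 30%, between 5% and 60%. This means an expected step of a number 27.2 percentage points higher from compound 2 to compound 4 (beyond the scatter), beyond the scatter.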

Compound 4, a percentage reported as activity, at one concentration (the size of the read-out at that concentration, not a potency): 65.2%
The estimate for compound 4 lay 35.2 percentage points below the measured number; the measured number lies above the stated range.
By their numbers in this assay, from the lowest: compounds 1 and 2 (each within the scatter of the next); then compound 3; then compound 4.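

In this assay, putting 3,4-dichlorophenyl on the carbonyl carbon in place of the arylamino arm of the urea costs most of the effect, with a number 62.4 percentage points higher from compound 2 to compound 4 (beyond the scatter) and a number 71.3 percentage points higher from compound 1 to compound 4 (beyond the scatter). Earlier, adding a chloro to that arm had moved the number only within the scatter, so this place tolerates a small edit but not this exchange. Nothing measured here explains the size of these steps. The compounds shown leave open whether the loss follows the lost amino link or the changed ring substituents, and how a methylene link or a carboxylic acid on that ring would read.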